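Dipropylamino in place of diethylamino: working notes

The compounds below may be only part of what the source reports. "The series", "measured", "known", "first", "only" and "open" are said of these compounds alone.

Compound 1 `CCCCCN(CCCCC)CCCOc1ccc(S(=O)(=O)c2c(C(C)C)cn3ccccc23)cc1`: 89.6 nM
Compound 2 `CCCCc1cn2ccccc2c1S(=O)(=O)c1ccc(OCCCN(CCC)CCC)cc1`: 570 nM
Compound 3 `CCN(CC)CCCOc1ccc(S(=O)(=O)c2c(C(C)C)cn3ccccc23)cc1`: 228 nM

In a functional assay (aorta) with Rattus norvegicus as the target (a higher number here means a weaker inhibitor, a lower number a stronger inhibitor), compound 3 gives 228 nM, the middle of the three numbers, lower than that of compound 2 and higher than that of compound 1. Compound 4 `CCCN(CCC)CCCOc1ccc(S(=O)(=O)c2c(C(C)C)cn3ccccc23)cc1` carries dipropylamino in place of diethylamino on a saturated chain carbon, three bonds along the chain from an oxygen on an aromatic ring. Among the measured compounds shown here, one measured step bears on this place, diethylamino in place of dipentylamino: a 2.5-fold higher number from compound 1 to compound 3 (0.41 log units; beyond the scatter). Dipropylamino falls between those two groups, so a smaller step towards the lower number is expected in this assay. The expected change is a 1.5-fold lower number from compound 3 to compound 4 (0.18 log units; within the scatter). Compound 4 is estimated at 150 nM, with an expected range of 75 nM to 300 nM.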

Compound 4, half-maximal inhibitory concentration: 102 nM
Compound 4: the middle estimate sits 1.5-fold (0.17 log units) above what was measured; measured number inside the range.
By their numbers in this assay, from the lowest: compounds 1 and 4 (each within the scatter of the next); then compound 3; then compound 2.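

In this assay, dipropylamino on the saturated chain carbon gives a clear change from diethylamino (a 2.2-fold lower number from compound 3 to compound 4 (0.35 log units; beyond the scatter)), whereas dipropylamino and dipentylamino cannot be told apart (a 1.1-fold higher number from compound 1 to compound 4 (0.06 log units; within the scatter)). With dipropylamino held constant, isopropyl in place of butyl on an aromatic carbon gives a larger step (a 5.6-fold lower number from compound 2 to compound 4 (0.75 log units; beyond the scatter)), so the aromatic carbon also affects the number. No measured evidence bears on the reason for these steps.

Dibutylamino and dimethylamino remain open at the amine position. Also open, going by these compounds, is whether a propyl or pentyl group on the aromatic carbon follows the step from butyl to isopropyl.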